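A few compounds are considered here, and "the series" means these few. Any claim that something is new, unique, unknown or untested is made for them only; others in the source may bear on it.

Measured so far:
- compound 1, `COc1ccc2[nH]c(C(=O)N3CC(=O)N(Cc4ccccc4)[C@@H](COc4ccccc4)C3)cc2c1`: 12200 nM
- compound 2, `COc1ccc2[nH]c(C(=O)N3CC(=O)N(Cc4ccccc4)[C@@H](CN4CCN(S(=O)(=O)c5ccccc5)CC4)C3)cc2c1`: 16900 nM
- compound 3, `COc1ccc2[nH]c(C(=O)N3CC(=O)N(Cc4c[nH]c5ccccc45)[C@@H](Cc4ccccc4)C3)cc2c1`: 10300 nM

These three compounds share a common core and were compared in a physicochemical assay for solubility, read by spectrophotometry, in phosphate buffer, with a stated time of 2 h, at pH 7.4; on this read-out higher numbers stand for higher solubility and lower numbers for lower solubility. On these numbers compound 1 stands second highest of the three; its nearest neighbour is compound 3 and its furthest is compound 2, yet both gaps fall within the usual scatter of repeated measurements, so the three cannot be told apart on this read-out. Compound 4, `COc1ccc2[nH]c(C(=O)N3CC(=O)N(Cc4ccccc4)[C@@H](CN4CC5CC5C4)C3)cc2c1`, has not yet been measured in this assay. It differs from compound 1 in one place: a group of 6 heavy atoms (5 carbon, 1 nitrogen; one three-membered non-aromatic ring of carbon only, one five-membered non-aromatic ring with 1 hetero atom) in place of a group of 7 heavy atoms (6 carbon, 1 oxygen; one six-membered aromatic ring of carbon only), on a saturated chain carbon bound to a saturated ring carbon. Going by the values given here, no step between measured compounds carries this same change, so the expectation rests only on the three numbers, whose spread is narrow. Since compound 2 gives 16900 nM with a different replacement at this place, a modest rise is expected for compound 4, one that may just reach beyond the scatter, as the expected step of a 2.3-fold higher number from compound 1 to compound 4 (0.36 log units; beyond the scatter) shows. Compound 4 is therefore expected to give 28000 nM, with a range from 9000 nM to 90000 nM.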

Compound 4, solubility: 17500 nM
Beside the measured number, compound 4's estimate is 1.6-fold (0.20 log units) above it; measured number inside the range.
By their numbers in this assay, from the lowest: compounds 3, 1, 2 and 4 (each within the scatter of the next).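

On a saturated chain carbon bound to a saturated ring carbon, replacing phenoxy with a group holding one three-membered ring of carbon only and one five-membered ring with 1 hetero atom gives a 1.4-fold higher number from compound 1 to compound 4 (0.16 log units; within the scatter) in this assay. Going by these compounds alone, this is the first step in the set where only one place changes, and it shows that this read-out does not separate the two groups at this position, even though the six-membered aromatic ring is gone. No measurement is available here to explain this result.

On these data alone, it remains open whether a carboxylic acid or a longer carbon chain at this position would give a step beyond the scatter. As far as these compounds go, it also remains open whether the same exchange would give a similar step in a compound that differs elsewhere from compound 1.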